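Fluoro in place of nitro: working notes on the series

The compounds below may be only part of what the source reports. "The series", "measured", "known", "first", "only" and "open" are said of these compounds alone.

In an ADME assay on HEK293 cells (Homo sapiens) for antiproliferative activity, read by MTT assay, with a stated time of 48 h (on this read-out lower numbers stand for stronger inhibition and higher numbers for weaker inhibition), compound 1 (`COc1ccc2nc(NC(c3cn(-c4ccccc4)nc3-c3ccc(Cl)cc3)c3c(O)ccc4ccccc34)sc2c1`) gives 56000 nM and compound 2 (`COc1ccc2nc(NC(c3cn(-c4ccccc4)nc3-c3ccc([N+](=O)[O-])cc3)c3c(O)ccc4ccccc34)sc2c1`) gives 46500 nM on the same read-out. Among the measured compounds shown here, these are the only two numbers so far, and they lie within the scatter of each other, so compound 2 stands level with compound 1. The change to compound 3 (`COc1ccc2nc(NC(c3cn(-c4ccccc4)nc3-c3ccc(F)cc3)c3c(O)ccc4ccccc34)sc2c1`) is fluoro in place of nitro on an aromatic carbon, para to a large group (fluoro in place of nitro on an aromatic carbon). For the measured compounds named here, the one measured step at this place (a 1.2-fold lower number from compound 1 to compound 2 (0.08 log units; within the scatter)) is nitro in place of chloro. It lies within the scatter and gives no ground for expecting more than scatter in this assay for this change. Going by the values given here, no measured compound yet carries fluoro. The estimated step is small and has no firm direction (a 1.1-fold higher number from compound 2 to compound 3 (0.03 log units; within the scatter)). Compound 3 is expected at 50000 nM (estimated range 28000 nM to 90000 nM).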

Compound 3, half-maximal inhibitory concentration: 58100 nM
Compound 3: the middle estimate sits 1.2-fold (0.07 log units) below what was measured; the measured number falls inside the stated range.
By their numbers in this assay, from the lowest: compounds 2, 1 and 3 (each within the scatter of the next).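

Fluoro in place of nitro gives a 1.2-fold higher number from compound 2 to compound 3 (0.10 log units; within the scatter) in this assay and fluoro in place of chloro gives a 1.0-fold higher number from compound 1 to compound 3 (0.02 log units; within the scatter) on the same read-out, so both new steps lie within the scatter. Among the compounds shown here, the single earlier step could not show this: nitro, chloro and fluoro, on an aromatic carbon para to a large group, now stand level in all three pairs, and none of the three groups separates from the others in this assay. No other measurement bears on this result, and the numbers alone give no reason for it.

On these data alone, whether a group of another kind at this carbon, such as an amine, a carboxylic acid or a longer chain, would move the number beyond the scatter remains open. As far as these compounds go, all three compounds share the rest of the structure, so it also remains open whether these groups would stay level on a changed core.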